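Swapping Trifluoromethyl for Fluoro: What Edema Inhibition to Expect

A few compounds are considered here, and "the series" means these few. Any claim that something is new, unique, unknown or untested is made for them only; others in the source may bear on it.

Measured compounds:
Compound 1 `O=C(N/N=C/c1ccc(-c2ccccc2)cc1)c1cnccn1` gives 47.7% in a functional assay on the whole organism (strain Swiss) for inhibition, with Mus musculus as the target, read by paw edema, with stated times of 40 min and 30 min, at a dose of 100 umol/kg by the oral route; on this read-out lower numbers stand for less inhibition and higher numbers for more inhibition at the one dose given (going by the name of the read-out).
Compound 2 `O=C(N/N=C/c1ccc(O)cc1)c1cnccn1` gives 42.3%.
Compound 3 `O=C(N/N=C/c1ccc(C(F)(F)F)cc1)c1cnccn1` gives 48.3%.

All three share one core and differ only in the group on one aromatic carbon. In this assay compound 3 stands highest of the three numbers, yet the steps leading to it, a number 0.6 percentage points higher from compound 1 to compound 3 (within the scatter) and a number 6 percentage points higher from compound 2 to compound 3 (within the scatter), both lie within the scatter, as does a number 5.4 percentage points lower from compound 1 to compound 2 (within the scatter). Going by the values given here, no compound's number can therefore be called higher than another's beyond the scatter; the three read as one level.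

The next compound, compound 4 `O=C(N/N=C/c1ccc(F)cc1)c1cnccn1`, carries a change at the same aromatic carbon: fluoro in place of trifluoromethyl on an aromatic carbon.

The three measured steps all bear on this change, since each swaps the group at this carbon, and each is within the scatter. A fluoro group differs from the trifluoromethyl it replaces only in what is counted above, and the earlier swaps, which moved between far more different groups, left the read-out flat. The expected step of a number 3.3 percentage points lower from compound 3 to compound 4 (within the scatter) is therefore none beyond the scatter.

Compound 4 is estimated at 45%, with a range from 35% to 55%.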

Compound 4, a percentage reported as inhibition, in the whole organism at one dose (the size of the read-out at that dose, not a potency): 33.1%
The estimate for compound 4 lay 11.9 percentage points above the measured number; the measured number lies below the stated range.
By their numbers in this assay, from the lowest: compounds 4, 2, 1 and 3 (each within the scatter of the next, the first and the last beyond it).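

Going by these compounds alone, this position is less indifferent than the first three compounds suggested: in this assay, a number 15.2 percentage points lower from compound 3 to compound 4 (beyond the scatter) and a number 14.6 percentage points lower from compound 1 to compound 4 (beyond the scatter), and these are the first steps in the set to pass beyond the scatter. Replacing trifluoromethyl with fluoro, with 4 heavy atoms leaving, 1 entering and no hydrogen-bond donor or acceptor counted on either side, is therefore enough to move this read-out, although compound 2 does not fit a clean split into two levels: a number 9.2 percentage points lower from compound 2 to compound 4 (within the scatter), and its step from compound 3 also stays within the scatter. Nothing available explains why fluoro gives a lower number than trifluoromethyl or phenyl here.

A chloro group or a methyl group on the same aromatic carbon could show whether the read-out changes gradually across groups of intermediate size or falls away only with fluoro. An amine or a carboxylic acid at this carbon would test whether compound 2 reflects something broader about groups that carry hydrogen-bond donors, a question that one hydroxy compound cannot settle.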